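A few compounds are considered here, and "the series" means these few. Any claim that something is new, unique, unknown or untested is made for them only; others in the source may bear on it.

Measured in an ADME assay on HFF cells (Homo sapiens) for cytotoxicity, with a stated time of 8 days; a lower number here means that less compound is tolerated, a higher number that more compound is tolerated:
- compound 1 `C=CCOc1nc(N)nc2c1ncn2/C=C1/CC1(CO)CO`: > 300000 nM
- compound 2 `CSc1nc(N)nc2c1ncn2/C=C1/CC1(CO)CO`: > 300000 nM
- compound 3 `CC(C)Sc1nc(N)nc2c1ncn2/C=C1/CC1(CO)CO`: > 300000 nM

Each of these entries is a limit of the assay and not a number. The series therefore has no numerical ranking, and compound 3 stands with the other two: the limit of > 300000 nM in this assay, at which 3 of the 3 values shown sit.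

The next change gives compound 4 `CCCCCCOc1nc(N)nc2c1ncn2/C=C1/CC1(CO)CO`, with hexyloxy in place of isopropylsulfanyl on an aromatic carbon.

The closest measured comparison is a step that the two limits leave unreadable from compound 1 to compound 3, which also exchanges an oxygen-linked group for isopropylsulfanyl on an aromatic carbon. The other two comparisons are a step that the two limits leave unreadable from compound 1 to compound 2 and a step that the two limits leave unreadable from compound 2 to compound 3. None of the three gives a size, so they show only that allyloxy, methylsulfanyl and isopropylsulfanyl all reach the limit in this assay. Hexyloxy has not been tested in this series, so the measured steps do not settle the outcome.

Compound 4 may well reach the same limit, but a number somewhat lower on the scale is also expected to be possible. The estimate therefore means an at least 1.5-fold lower number from compound 3 to compound 4 (0.17 log units; that floor lies within the scatter), an expected move towards less compound being tolerated.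

For compound 4 the estimated value is 200000 nM, with an expected range from 60000 nM to 300000 nM.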

Compound 4, half-maximal cytotoxic concentration: > 200000 nM
Compound 4 was reported as a limit (the forecaster's own chance of this, stated with the estimate: 55%); the middle value lies on the limit itself.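

Compound 4 gives > 200000 nM, a limit and not a number. For the compounds shown here, with all four entries being limits, no step between compound 4 and compound 1, compound 2 or compound 3 can be read. The compounds shown leave open where any of the four would fall on the scale and whether any of these groups changes how much compound is tolerated.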